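The source may report more compounds than this note shows. Statements on the series, on what has been measured and on what is new or still open speak of the compounds shown alone.

Measured so far in a functional assay on A2780 cells (Homo sapiens) for inhibition, with a stated time of 72 h, tested at 10 uM; a lower number here means less inhibition of growth, a higher number more inhibition of growth at the concentration tested: compound 1 `CC1(C)CCOc2ccc(NC(=S)Nc3ccc(OC(F)(F)F)cc3)cc21` gives 16%; compound 2 `CC1(C)CC(C)(C)c2cc(NC(=O)Nc3ccc([N+](=O)[O-])cc3)ccc2O1` gives 79%; compound 3 `CC1(C)CC(C)(C)c2cc(NC(=O)Nc3ccc(C#N)cc3)ccc2O1` gives 93%.

Compound 3 stands highest of these three in this assay, with compound 2 nearest and compound 1 far below. Compound 4 `CC1(C)CC(C)(C)c2cc(NC(=O)Nc3ccc(C(F)(F)F)cc3)ccc2O1` differs from compound 3 in one place: trifluoromethyl in place of cyano on an aromatic carbon. Among the measured compounds shown here, no measured step introduces a trifluoromethyl group on this core. For the measured compounds named here, the only step on the same core, a number 14 percentage points higher from compound 2 to compound 3 (beyond the scatter), shows that swapping one group at this aromatic carbon for another moved the number only modestly. Compound 1 has a different core and a thiourea, so its low value says little about compound 4. Compound 4 is thus expected to stay near compound 3, with an expected step of a number 8 percentage points lower from compound 3 to compound 4 (within the scatter). The estimate for compound 4 is 85%, between 65% and 98%.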

Compound 4, percent growth inhibition at one concentration: 88.4%
The estimate for compound 4 lay 3.4 percentage points below the measured number; low and high end bracket the measured number.
By their numbers in this assay, from the lowest: compound 1; then compounds 2, 4 and 3 (each within the scatter of the next, the first and the last beyond it).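

In this assay, the step of a number 4.6 percentage points lower from compound 3 to compound 4 (within the scatter) shows that this aromatic carbon, para to a large group, accepts trifluoromethyl about as well as cyano, so neither the triple bond nor the hydrogen-bond acceptor of cyano is needed to keep the number high. The step of a number 9.4 percentage points higher from compound 2 to compound 4 (within the scatter) adds that compound 4 cannot be told apart from compound 2 either, although compound 2 and compound 3 do differ beyond the scatter.

On these data alone, whether an amine or a carboxylic acid on this carbon would keep the number high remains open. Nothing measured here explains why these groups give such similar numbers.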